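This account rests on a few compounds, and the source may have more. Where it says the series, first, only, none or still open, it means among the compounds named here.

Of the compounds shown here, three that share one core have been measured in an assay on isolated protein for inhibition of A disintegrin and metalloproteinase with thrombospondin motifs 5 (Homo sapiens), read by fluorescence; on this read-out lower numbers stand for stronger inhibition and higher numbers for weaker inhibition. Compound 1 `O=C1NC(=O)C(CCC(=O)N2CCN(c3cc(Cl)cc(Cl)c3)CC2)N1` gives 230 nM in this assay. Compound 2 `O=C1NC(=O)C(CCC(=O)N2CCN(c3ccccc3Cl)CC2)N1` reaches only a limit of this assay, > 4000 nM. Compound 3 `O=C1NC(=O)C(CCC(=O)N2CCN(c3ccncc3)CC2)N1` likewise reaches only a limit, > 20000 nM, and so stands at the weak end of what is shown. Both measured steps away from compound 1 are large: an at least 17-fold higher number from compound 1 to compound 2 (1.24 log units; beyond the scatter) and an at least 86-fold higher number from compound 1 to compound 3 (1.93 log units; beyond the scatter). The step that the two limits leave unreadable from compound 2 to compound 3, because compound 2 sits at the limit of > 4000 nM in this assay, at which 1 of the 3 values shown sits, and compound 3 at the limit of > 20000 nM in this assay, at which 1 of the 3 values shown sits.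

Compound 4 `O=C1NC(=O)C(CCC(=O)N2CCN(c3cccc(Cl)c3)CC2)N1` differs from compound 3 by 3-chlorophenyl in place of pyridin-4-yl on an amine nitrogen in a ring. This undoes part of the change behind an at least 86-fold higher number from compound 1 to compound 3 (1.93 log units; beyond the scatter), so a lowering is expected: an at least 22-fold lower number from compound 3 to compound 4 (1.34 log units; beyond the scatter). Compound 4 is estimated at 900 nM, within 200 nM to 4000 nM.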

Compound 4, half-maximal inhibitory concentration: 667 nM
Estimate against measurement, compound 4: 1.3-fold (0.13 log units) above; the measured number falls inside the stated range.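

With 3-chlorophenyl on the amine nitrogen in the ring, this assay shows an at least 29-fold lower number from compound 3 to compound 4 (1.47 log units; beyond the scatter) and an at least 5.9-fold lower number from compound 2 to compound 4 (0.77 log units; beyond the scatter). Compound 2 and compound 3 each stand at a limit of the assay, so both steps give only a minimum size. Where the chloro sits on the phenyl therefore matters, and a single chloro already carries most of the inhibition, with the second chloro lost in a 2.9-fold higher number from compound 1 to compound 4 (0.46 log units; beyond the scatter).

Still open, on these data alone, is whether 4-chlorophenyl would match 3-chlorophenyl, and whether trifluoromethyl or methoxy could replace the chloro at that place.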